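Indazolyl for carbamoylphenyl: microsomal clearance outlook

The compounds below may be only part of what the source reports. "The series", "measured", "known", "first", "only" and "open" are said of these compounds alone.

Going by the values given here, compound 3 `NC(=O)c1cccc(-c2cc(C(O)(C(F)(F)F)C(F)(F)F)cnc2N2CCN(S(=O)(=O)c3ccc(N)nc3)CC2)c1` is the one member of the series with a numeric value: in an ADME assay (liver) for metabolic stability, with Liver microsome (Homo sapiens) as the target, using microsomes and NADPH, with a stated time of 30 min, tested at 1 uM (on this read-out higher numbers stand for fast clearance and lower numbers for slow clearance), compound 3 gives 17 mL.min-1.g-1. The other two values are limits of the assay, (the limit of < 14 mL.min-1.g-1 in this assay, at which 2 of the 3 values shown sit). Compound 1 `COc1cc(C(O)(C(F)(F)F)C(F)(F)F)cnc1N1CCN(S(=O)(=O)c2ccc(N)nc2)CC1` gives < 14 mL.min-1.g-1 in this assay, a limit. Compound 2 `Nc1ccc(S(=O)(=O)N2CCN(c3ncc(C(O)(C(F)(F)F)C(F)(F)F)cc3C#CC3CC3)CC2)cn1` gives < 14 mL.min-1.g-1, again a limit. From these follow an at least 1.2-fold higher number from compound 1 to compound 3 (0.08 log units; that floor lies within the scatter) and an at least 1.2-fold higher number from compound 2 to compound 3 (0.08 log units; that floor lies within the scatter), while a step that the two limits leave unreadable from compound 1 to compound 2.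

Compound 4 `Nc1ccc(S(=O)(=O)N2CCN(c3ncc(C(O)(C(F)(F)F)C(F)(F)F)cc3-c3ccc4[nH]ncc4c3)CC2)cn1` differs from compound 3 in one place: 1H-indazol-5-yl in place of 3-carbamoylphenyl on an aromatic carbon. Among the compounds with values here, no measured step exchanges one aryl group for another aryl group of this kind, so the closest guide is that every change at this position so far, whether methoxy, 2-cyclopropylethynyl or 3-carbamoylphenyl, has left the readings in this assay either at the limit or barely above it. Compound 4 is therefore expected to stay close to compound 3, giving an estimated 15 mL.min-1.g-1 with a range from 7 mL.min-1.g-1 to 32 mL.min-1.g-1. This estimate amounts to an expected 1.1-fold lower number from compound 3 to compound 4 (0.05 log units; within the scatter), inside the scatter, with a fair chance that only a limit is reported.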

Compound 4, intrinsic clearance in microsomes: 27 mL.min-1.g-1
For compound 4 the middle estimate is 1.8-fold (0.26 log units) below the measured one; low and high end bracket the measured number.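

Within this assay the exchange of one aryl group for another at this position can now be read directly, with a 1.6-fold higher number from compound 3 to compound 4 (0.20 log units; within the scatter) for 1H-indazol-5-yl in place of 3-carbamoylphenyl. Against 2-cyclopropylethynyl the reading is an at least 1.9-fold higher number from compound 2 to compound 4 (0.28 log units; that floor lies within the scatter) and against methoxy it is an at least 1.9-fold higher number from compound 1 to compound 4 (0.28 log units; that floor lies within the scatter), so no change at this position is yet shown to lie beyond the scatter. Compound 3 and compound 4 now carry numeric readings, while compound 1 and compound 2 remain limits: the limit of < 14 mL.min-1.g-1 in this assay, at which 2 of the 4 values shown sit.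

From the compounds shown here alone, the true size of the steps from compound 1 and compound 2 stays open, as only floors exist for them. Also open, going by these compounds, is whether a primary amine or a carboxylic acid on the aryl group at this position would move the reading beyond the scatter.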